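Swapping the Aryl Group on a Triazole Ring

The source may hold more compounds than are shown below. What is called first, only, known or untested is meant among the compounds shown, and "the series" means these compounds.

This series of compounds shares one core, carrying a methoxy group, a prenyl chain, an acrylic acid and a triazole ring that bears a varying aromatic group on one of its nitrogens. Compound 1 `COc1ccc(/C=C\C(=O)O)c(OCc2cn(-c3ccccc3F)nn2)c1CC=C(C)C` carries a 2-fluorophenyl group there; in a functional assay on PC-3 cells (Homo sapiens) for cytotoxicity, read by MTT assay, with a stated time of 24 h (on this read-out higher numbers stand for weaker inhibition and lower numbers for stronger inhibition), compound 1 gives 24200 nM. Compound 2 `COc1ccc(/C=C\C(=O)O)c(OCc2cn(-c3ccccc3I)nn2)c1CC=C(C)C` carries a 2-iodophenyl group, and in this assay compound 2 shows "not determined" (no result reported). Compound 3 `COc1ccc(/C=C\C(=O)O)c(OCc2cn(-c3ccc(C#N)cc3)nn2)c1CC=C(C)C` carries a 4-cyanophenyl group, and in this assay compound 3 likewise shows "not determined" (no result reported), so no number places it on the scale; the only measured point in the set is compound 1.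

Compound 4 `COc1ccc(/C=C\C(=O)O)c(OCc2cn(-c3cccc([N+](=O)[O-])c3)nn2)c1CC=C(C)C` differs from compound 3 in one place: 3-nitrophenyl in place of 4-cyanophenyl on an aromatic nitrogen. For the measured compounds named here, no measured pair in the set allows the size of such a step to be read off, so the expectation rests on compound 1 alone. Given that compound 1 gives 24200 nM, a weak result of similar size is expected for compound 4, with no step beyond the usual scatter assumed in either direction. For compound 4 in this assay a value of about 25000 nM is estimated, expected to fall between 8000 nM and 80000 nM.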

Compound 4, half-maximal inhibitory concentration: 42100 nM
Compound 4: the middle estimate sits 1.7-fold (0.23 log units) below what was measured, within the range that was stated.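

Exchanging 2-fluorophenyl for 3-nitrophenyl on an aromatic nitrogen gives, in this assay, a 1.7-fold higher number from compound 1 to compound 4 (0.24 log units; within the scatter), so this position accepts two quite different aryl groups without a reading that separates them. For the compounds shown here, this is the first comparison in the set that gives the size of a change here, and in this single pair the identity of the group and its place on the phenyl ring do not shift the result beyond the usual scatter. Compound 2 and compound 3 have no reported number, so their steps cannot be read, including the step from 4-cyanophenyl to 3-nitrophenyl; nothing measured here explains the reading of either compound with a number.

The compounds shown leave open whether an amine or a hydroxyl group on the phenyl ring, or a longer chain in place of that ring, would move the reading beyond the scatter. They also leave open whether one group gives the same reading at two places on the phenyl ring; the two measured compounds differ in both the group and its place.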